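Sulfonyl aryl swap in a fluoroquinoline sulfone series

The compounds below may be only part of what the source reports. "The series", "measured", "known", "first", "only" and "open" are said of these compounds alone.

Two compounds of the series have numbers in an ADME assay on microsomes from liver (Homo sapiens) for metabolic stability, tested at 2.5 uM; a higher number here means faster removal of the compound, a lower number slower removal. Compound 1 `N#Cc1cccc(S(=O)(=O)c2cnc3cc(F)ccc3c2-c2cccc(Cl)c2)c1` gives 0.99 mL/min in this assay. Compound 2 `COc1cccc(-c2c(S(=O)(=O)c3ccc(C)c(C)c3)cnc3cc(F)ccc23)c1` gives 8.78 mL/min in this assay, the higher of the two numbers; the gap between compound 2 and compound 1 lies beyond the scatter of repeated measurements, so compound 2 is removed faster than compound 1. Within the data shown here, the two measured compounds differ in more than one place, so no single step between them can be read off.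

Compound 3 `COc1cccc(-c2c(S(=O)(=O)c3cccc(C#N)c3)cnc3cc(F)ccc23)c1` is not yet measured. It differs from compound 2 by one change: 3-cyanophenyl in place of 3,4-dimethylphenyl on a sulfonyl sulfur. Compound 3 thereby carries the same group on the sulfonyl sulfur as compound 1, while keeping the rest of compound 2.

Because compound 1 gives 0.99 mL/min in this assay with the 3-cyanophenyl on the sulfonyl sulfur, the expected step of a 3.5-fold lower number from compound 2 to compound 3 (0.55 log units; beyond the scatter) is downward and beyond the scatter, though not necessarily the full way to compound 1. The estimate for compound 3 in this assay is 2.5 mL/min, with a range from 1 mL/min to 6 mL/min.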

Compound 3, intrinsic clearance in a liver preparation (reported as CLH), per the amount of preparation that the assay uses: 1.83 mL/min
The estimate for compound 3 lay 1.4-fold (0.14 log units) above the measured number, within the range that was stated.
By their numbers in this assay, from the lowest: compounds 1 and 3 (each within the scatter of the next); then compound 2.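

Replacing 3,4-dimethylphenyl with 3-cyanophenyl on the sulfonyl sulfur gives a 4.8-fold lower number from compound 2 to compound 3 (0.68 log units; beyond the scatter) in this assay with the rest of compound 2 unchanged, so this modest step can now be assigned to the group on the sulfonyl sulfur, which the first two compounds could not show. With 3-cyanophenyl held on that sulfur, methoxy in place of chloro on an aromatic carbon gives a 1.8-fold higher number from compound 1 to compound 3 (0.27 log units; within the scatter) and so leaves the two compounds indistinguishable in this read-out. No measured information here explains either step.

The compounds shown leave open whether the step from 3,4-dimethylphenyl to 3-cyanophenyl holds in size when chloro rather than methoxy sits on the aromatic carbon. They also leave open how a phenyl ring carrying a carboxylic acid, a primary amide or a morpholine on the sulfonyl sulfur would stand in this assay against the 3-cyanophenyl of compound 3.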